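The compounds below may be only part of what the source reports. "The series", "measured", "known", "first", "only" and "open" are said of these compounds alone.

Three compounds have been measured in a functional assay on CHO cells for antagonist activity at sphingosine 1-phosphate receptor 2 (Homo sapiens), read by GTPgammaS binding; on this read-out higher numbers stand for weaker inhibition and lower numbers for stronger inhibition:

compound 1 `CC(C(=O)O)c1nn(Cc2cn3cc(OCC4CC4)c(Cl)cc3n2)c2ccccc2c1=O`, 31 nM
compound 2 `COC(C(=O)O)c1nn(Cc2cn3cc(OCC4CC4)c(Cl)cc3n2)c2ccccc2c1=O`, 58 nM
compound 3 `O=C(O)Cn1nc(CC(=O)Nc2ccc(OC(F)(F)F)c(Cl)c2)c2ccccc2c1=O`, 754 nM

Compound 2 holds the second highest number of the three. Its nearest neighbour is compound 1: the step of a 1.9-fold higher number from compound 1 to compound 2 (0.27 log units; within the scatter) stays within the scatter, so the two cannot be ranked against each other. Its furthest neighbour is compound 3, whose number lies beyond the scatter above that of compound 2.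

Compound 4 `CC(C)(C(=O)O)c1nn(Cc2cn3cc(OCC4CC4)c(Cl)cc3n2)c2ccccc2c1=O` differs from compound 2 by 1-carboxy-1-methylethyl in place of carboxy(methoxy)methyl on an aromatic carbon. Going by the values given here, only one measured step bears on this change, a 1.9-fold higher number from compound 1 to compound 2 (0.27 log units; within the scatter), and compound 4 runs it in reverse as far as the methoxy is concerned while adding a second methyl on the same carbon; no measured pair shows what that second methyl does. The expectation is therefore a number close to that of compound 1, with the step of a 1.7-fold lower number from compound 2 to compound 4 (0.22 log units; within the scatter) expected to remain within the scatter. Compound 4 is estimated at 35 nM, in the range 12 nM to 110 nM.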

Compound 4, half-maximal inhibitory concentration: 105 nM
Beside the measured number, compound 4's estimate is 3.0-fold (0.48 log units) below it; the measured number falls inside the stated range.
By their numbers in this assay, from the lowest: compounds 1, 2 and 4 (each within the scatter of the next, the first and the last beyond it); then compound 3.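

Putting methyl in place of hydrogen on the saturated chain carbon gives a 3.4-fold higher number from compound 1 to compound 4 (0.53 log units; beyond the scatter), the first measured sign that a second methyl on this carbon shifts the number, though only modestly. The exchange of carboxy(methoxy)methyl for 1-carboxy-1-methylethyl gives a 1.8-fold higher number from compound 2 to compound 4 (0.26 log units; within the scatter), so compound 2 and compound 4 cannot be ranked, and this carbon carries either group with no readable difference. No measurement at hand accounts for the effect of the second methyl.

The compounds shown leave open what this position gives with a hydroxyl or an ethyl on the chain carbon, or with two hydrogens there, as in a plain carboxymethyl group. They also leave open whether an amide or a methyl ester can stand in place of the carboxylic acid.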